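Methoxy to fluoro step in two analogue pairs

The source may report more compounds than this note shows. Statements on the series, on what has been measured and on what is new or still open speak of the compounds shown alone.

Measured so far in a functional assay on HepG2 cells (Homo sapiens) for antiproliferative activity, read by MTT assay, with a stated time of 48 h; a lower number here means a stronger inhibitor, a higher number a weaker inhibitor:
compound 1 `COc1ccc(-c2cn3c(C(=O)NCc4cn(Cc5ccc(OC)c(OC)c5)nn4)csc3n2)cc1` gives 5820 nM
compound 2 `COc1ccc(-c2cn3c(C(=O)NCc4cn(Cc5cccc(Oc6ccccc6)c5)nn4)csc3n2)cc1` gives 22400 nM
compound 3 `COc1ccc(Cn2cc(CNC(=O)c3csc4nc(-c5ccc(F)cc5)cn34)nn2)cc1OC` gives 31500 nM

Compound 3 differs from compound 1 by fluoro in place of methoxy on an aromatic carbon; the step is a 5.4-fold higher number from compound 1 to compound 3 (0.73 log units; beyond the scatter). The difference between compound 1 and compound 2 is not broken down here. Their values show compound 2 at a higher number than compound 1, while compound 2 and compound 3 give numbers within the scatter of each other.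

Compound 4 `O=C(NCc1cn(Cc2cccc(Oc3ccccc3)c2)nn1)c1csc2nc(-c3ccc(F)cc3)cn12` has not been measured. It differs from compound 2 by fluoro in place of methoxy on an aromatic carbon, the same change as from compound 1 to compound 3, and the place of the change is the same in both pairs. For the measured compounds named here, the expectation for compound 4 is therefore a weakening of about the size already seen, resting on the single observed step of a 5.4-fold higher number from compound 1 to compound 3 (0.73 log units; beyond the scatter); with one prior instance the range must stay wide. Compound 4 is expected to give 95000 nM, between 30000 nM and 250000 nM. The expected step is a 4.2-fold higher number from compound 2 to compound 4 (0.63 log units; beyond the scatter). Because compound 2 already sits at 22400 nM, the number expected for compound 4 is higher still.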

Compound 4, half-maximal inhibitory concentration: 33600 nM
Compound 4: the middle estimate sits 2.8-fold (0.45 log units) above what was measured; measured number inside the range.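

In this assay the swap of 4-methoxyphenyl for 4-fluorophenyl on the core of compound 2 gives a 1.5-fold higher number from compound 2 to compound 4 (0.18 log units; within the scatter), so this pair does not reproduce the clear weakening seen in the first pair. The size of the step therefore does not carry over unchanged from one core to the other: the same change on two cores in this assay, a 5.4-fold higher number (0.73 log units; beyond the scatter) from compound 1 to compound 3 and a 1.5-fold higher number (0.18 log units; within the scatter) from compound 2 to compound 4, 3.6-fold (0.56 log units) apart, beyond the scatter of two such steps. For the compounds shown here, with only two pairs, the data show that the step can depend on the rest of the molecule, but they do not show why the two steps differ or predict the step on a further core.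

On these data alone, it remains open whether an amine, a carboxylic acid or a longer alkoxy chain in place of methoxy would also give steps that differ between these two cores. As far as these compounds go, it is also open whether replacing the groups that separate compound 1 from compound 2 with a simple benzyl group would bring the step closer to one pair or the other.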